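The compounds below may be only part of what the source reports. "The series", "measured", "known", "first", "only" and "open" are said of these compounds alone.

Three compounds share one core. Compound 1 `COc1ccc(C(=O)c2cc(OC)c(OC)c(OC)c2)cc1NC(=O)/C=C/c1cc(OC)c(OC)c(OC)c1` gives 5200 nM in a functional assay on COLO 205 cells (Homo sapiens) for cytotoxicity, read by MTT assay, with a stated time of 72 h; a lower number here means a stronger inhibitor, a higher number a weaker inhibitor. Compound 2 `COc1ccc(C(=O)c2cc(OC)c(OC)c(OC)c2)cc1NC(=O)/C=C/c1ccc(C(F)(F)F)cc1` gives 2600 nM in this assay, and the step of a 2.0-fold lower number from compound 1 to compound 2 (0.30 log units; within the scatter) is no larger than ordinary repeat-to-repeat variation. Compound 3 `COc1cc(C(=O)c2cc(OC)c(OC)c(OC)c2)cc(NC(=O)/C=C/c2cc(OC)c(OC)c(OC)c2)c1OC` gives 5300 nM in this assay; the step of a 1.0-fold higher number from compound 1 to compound 3 (0.01 log units; within the scatter) is likewise within that variation. Compound 3 thus holds the highest of the three numbers, with compound 1 essentially level with it and compound 2 separated from it by a gap beyond the scatter.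

Compound 4 `COc1cccc(/C=C/C(=O)Nc2cc(C(=O)c3cc(OC)c(OC)c(OC)c3)cc(OC)c2OC)c1` differs from compound 3 by 3-methoxyphenyl in place of 3,4,5-trimethoxyphenyl on a double-bonded chain carbon bound to a double-bonded chain carbon. Going by the values given here, the one measured step at the same place is a 2.0-fold lower number from compound 1 to compound 2 (0.30 log units; within the scatter), where exchanging that same ring for a different one shifted the number only within the scatter. The step of a 1.0-fold higher number from compound 1 to compound 3 (0.01 log units; within the scatter) sits at another place and says little here. The expected step is therefore a 1.3-fold lower number from compound 3 to compound 4 (0.12 log units; within the scatter), modest and, if anything, toward a lower number. For compound 4 the estimate is 4000 nM, expected to fall between 1500 nM and 10000 nM.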

Compound 4, half-maximal inhibitory concentration: 10700 nM
The estimate for compound 4 lay 2.7-fold (0.43 log units) below the measured number; the whole stated range lies below it.
By their numbers in this assay, from the lowest: compounds 2, 1 and 3 (each within the scatter of the next, the first and the last beyond it); then compound 4.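

On the core of compound 3, trading 3,4,5-trimethoxyphenyl for 3-methoxyphenyl on a double-bonded chain carbon bound to a double-bonded chain carbon gives a 2.0-fold higher number from compound 3 to compound 4 (0.31 log units; beyond the scatter) in this assay, a modest weakening. Going by these compounds alone, this is the first exchange at this place to go beyond the scatter, as the earlier one, a 2.0-fold lower number from compound 1 to compound 2 (0.30 log units; within the scatter), stayed within it, so the ring here is not wholly indifferent to change, although a single step of this size shows only a small sensitivity. Nothing available explains why the number moved.

The compounds shown leave open whether 3-methoxyphenyl would act the same way on the core of compound 1, and whether 4-(trifluoromethyl)phenyl would on the core of compound 3. As far as these compounds go, how this ring would respond to an amine or a carboxylic acid also remains unknown.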